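Methylating the sulfamoyl nitrogen of a thiourea vanilloid antagonist

The source may hold more compounds than are shown below. What is called first, only, known or untested is meant among the compounds shown, and "the series" means these compounds.

Measured so far:
compound 1 `CCS(=O)(=O)Nc1ccc(C/N=C(\S)NCc2ccc(C(C)(C)C)cc2)cc1` gives 1300 nM
compound 2 `CC(C)S(=O)(=O)Nc1ccc(C/N=C(\S)NCc2ccc(C(C)(C)C)cc2)cc1` gives 3800 nM
compound 3 `CNS(=O)(=O)Nc1ccc(C/N=C(\S)NCc2ccc(C(C)(C)C)cc2)cc1` gives 2500 nM

In a functional assay for antagonist activity at Vanilloid receptor (Rattus norvegicus) (a higher number here means a weaker inhibitor, a lower number a stronger inhibitor), compound 3 gives 2500 nM, the second highest of the three numbers; its gaps to the others are both within the scatter: a 1.9-fold higher number from compound 1 to compound 3 (0.28 log units; within the scatter) and a 1.5-fold lower number from compound 2 to compound 3 (0.18 log units; within the scatter). Compound 4 `CN(C)S(=O)(=O)Nc1ccc(C/N=C(\S)NCc2ccc(C(C)(C)C)cc2)cc1` differs from compound 3 by methyl in place of hydrogen on a sulfonamide nitrogen. Within the data shown here, the only measured step that adds a methyl is a 2.9-fold higher number from compound 1 to compound 2 (0.47 log units; beyond the scatter), a modest rise, though that methyl entered a chain carbon rather than a sulfonamide nitrogen, so it bears on the present change only loosely. Compound 4 is therefore expected to give a somewhat higher number, a 1.4-fold higher number from compound 3 to compound 4 (0.15 log units; within the scatter). The estimate for compound 4 is 3500 nM, with a range from 1200 nM to 10000 nM.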

Compound 4, half-maximal inhibitory concentration: 14600 nM
Estimate against measurement, compound 4: 4.2-fold (0.62 log units) below; the whole stated range lies below it.
By their numbers in this assay, from the lowest: compounds 1, 3 and 2 (each within the scatter of the next, the first and the last beyond it); then compound 4.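

Among these compounds, a second methyl on this sulfonamide nitrogen sets the dimethylamino group apart from the methylamino, isopropyl and ethyl groups, which the earlier compounds did not show: the steps are a 5.8-fold higher number from compound 3 to compound 4 (0.77 log units; beyond the scatter) and a 3.8-fold higher number from compound 2 to compound 4 (0.58 log units; beyond the scatter) and an 11-fold higher number from compound 1 to compound 4 (1.05 log units; beyond the scatter) with each beyond the scatter. Replacing the remaining hydrogen on this nitrogen therefore matters here, although compound 3 itself stays within the scatter of both compound 1 and compound 2. Nothing available accounts for this loss of potency.

As far as these compounds go, whether an unsubstituted amino group would match compound 3 remains open. So does whether an ethyl on this nitrogen, or a pyrrolidine or morpholine in place of dimethylamino, would weaken inhibition further.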